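The compounds below may be only part of what the source reports. "The series", "measured", "known", "first", "only" and "open" are said of these compounds alone.

Measured in a functional assay on HT-29 cells (Homo sapiens) for cytotoxicity, read by sulforhodamine B assay; on this read-out higher numbers stand for weaker inhibition of growth and lower numbers for stronger inhibition of growth:

- compound 1 `CC1=CC[C@@H]([C@@](C)(O)CCCC(C)(C)NC(=S)N/N=C\c2ccc(C)cc2)CC1`: 10400 nM
- compound 2 `CC1=CC[C@@H]([C@@](C)(O)CCCC(C)(C)NC(=S)N/N=C\c2ccccc2[N+](=O)[O-])CC1`: 6940 nM

In this assay compound 2, at 6940 nM, stands within the scatter of compound 1, at 10400 nM, so the numbers shown do not separate the two. The next compound, compound 3 `CC1=CC[C@@H]([C@@](C)(O)CCCC(C)(C)NC(=S)N/N=C\c2cccc(Cl)c2)CC1`, has not yet been measured. It carries 3-chlorophenyl in place of 2-nitrophenyl on a carbon with a double bond to nitrogen, and the rest of the structure is unchanged.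

Within the data shown here, only one measured step bears on this change: a 1.5-fold lower number from compound 1 to compound 2 (0.18 log units; within the scatter). That step put 2-nitrophenyl in place of 4-methylphenyl on the same carbon and stayed within the scatter. Among the measured compounds shown here, it is a single step, and no measured compound carries 3-chlorophenyl, so the evidence is thin. On this basis, no step beyond the scatter is expected in this assay, and neither direction is favoured. The expected step is a 1.2-fold higher number from compound 2 to compound 3 (0.06 log units; within the scatter). For compound 3 the estimated value is 8000 nM, with an expected range from 3500 nM to 18000 nM.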

Compound 3, concentration for 50% growth inhibition: 6890 nM
For compound 3 the middle estimate is 1.2-fold (0.06 log units) above the measured one; measured number inside the range.
By their numbers in this assay, from the lowest: compounds 3, 2 and 1 (each within the scatter of the next).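

On the carbon with a double bond to nitrogen, a third substituent now stands in this assay, and its number stays within the scatter of both others: against 2-nitrophenyl (a 1.0-fold lower number from compound 2 to compound 3 (0.00 log units; within the scatter)) and against 4-methylphenyl (a 1.5-fold lower number from compound 1 to compound 3 (0.18 log units; within the scatter)). What had been a single step is now a set of three compounds that the read-out does not separate, even though 2-nitrophenyl counts hydrogen-bond acceptors and 3-chlorophenyl counts none, so exchanging these two groups at this place gives no readable difference. Nothing measured here offers a reason for this result.

All three compounds carry a substituted phenyl ring at this place, so they leave open whether the flat picture holds for something quite different there, such as a carboxylic acid, a dimethylamino group or a longer chain. They also leave open whether the number would move at all with a change elsewhere in the shared core, for example a carbonyl where the sulfur now stands.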